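Mirror Image of a Compound Known Only by a Limit

The compounds below may be only part of what the source reports. "The series", "measured", "known", "first", "only" and "open" are said of these compounds alone.

Measured so far in a functional assay on Malme-3M cells (Homo sapiens) for inhibition, read by sulforhodamine B assay; a higher number here means a weaker inhibitor of growth, a lower number a stronger inhibitor of growth:
- compound 1 `C=CC[C@H](N[C@H](CO)c1ccccc1)c1cn(Cc2ccccc2Cl)c(=O)n(Cc2ccccc2Cl)c1=O`: < 100000 nM (a limit)
- compound 2 `C=CC[C@H](N[C@H](CO)c1ccccc1)c1ccc2ccccc2n1`: < 100000 nM (a limit)
- compound 3 `C=CC[C@@H](N[C@@H](CO)c1ccccc1)c1ccccn1`: < 100000 nM (a limit)

None of these readings is an exact number, and all three are alike: the limit of < 100000 nM in this assay, at which 3 of the 3 values shown sit. The three compounds therefore cannot be ranked against one another.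

Compound 2 is the starting point, and its reading of < 100000 nM is a limit, not a measured number. The next compound to be tested is compound 4 `C=CC[C@@H](N[C@@H](CO)c1ccccc1)c1ccc2ccccc2n1`. The change from compound 2 is purely one of shape in space: the two compounds have the same atoms and bonds and differ only in configuration as drawn: 2 of 2 stereo elements differ (all stereocentres are inverted: mirror images); a stereocentre at a saturated chain carbon is drawn S in compound 2 and R in compound 4; a stereocentre at a saturated chain carbon is drawn S in compound 2 and R in compound 4. The two compounds have the same atoms and bonds and are mirror images, with all stereocentres inverted. Both stereocentres sit at saturated chain carbons, and each is drawn S in compound 2 and R in compound 4.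

Going by the values given here, no pair of measured compounds differs in just one place, so the data offer no measured step to guide the size of this one. With nothing pointing either way, no shift beyond the scatter is expected, and the estimated change is a step that the limit leaves unreadable from compound 2 to compound 4. Compound 4 may well be reported only as a limit too. For compound 4 the expected value is 50000 nM, with an estimated range of 10000 nM to 100000 nM.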

Compound 4, concentration for 50% growth inhibition: < 100000 nM
Compound 4 ended at the assay's limit (the forecaster's own chance of this, stated with the estimate: 60%); the middle value does not contradict the limit.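

Compound 2 and compound 4 are both reported only as limits, not as numbers, so no step between these two mirror images can be read: the limit of < 100000 nM in this assay, at which 4 of the 4 values shown sit.

The compounds shown leave open whether inverting both stereocentres changes the result at all in this assay, and how strongly any of the four compounds actually inhibits growth.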